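The compounds below may be only part of what the source reports. "The series", "measured", "known", "first", "only" and "open" are said of these compounds alone.

Compound 1 `CS(=O)(=O)CCCn1c(Cn2c(=O)n(C3CC3)c3ccncc32)cc2cc(Cl)ccc21` sits only at a limit in an ADME assay on HeLa cells (Homo sapiens) for cytotoxicity, read by ATP content, with a stated time of 3 days; a higher number here means that more compound is tolerated, a lower number that less compound is tolerated: compound 1 gives > 50000 nM, which is a limit of the assay and not a number. Compound 2 `CC(C)(O)CCCn1c(Cn2c(=O)n(C3CC3)c3ccncc32)cc2cc(Cl)ccc21` gives > 50000 nM, also a limit. Compound 3 `CS(=O)(=O)CCCn1c(Cn2c(=O)n(C3CC3)c3ccncc32)cc2ccccc21` gives > 100000 nM, likewise a limit. The two measured steps, a step that the two limits leave unreadable from compound 1 to compound 2 and a step that the two limits leave unreadable from compound 1 to compound 3, are therefore unreadable in size, and neither touches the cyclopropyl. Compound 4 `CS(=O)(=O)CCCn1c(Cn2c(=O)n(C3COC3)c3ccncc32)cc2cc(Cl)ccc21` differs from compound 1 by oxetan-3-yl in place of cyclopropyl on an aromatic nitrogen. Among the compounds with values here, with the limit of > 50000 nM in this assay, at which 2 of the 3 values shown sit, and the limit of > 100000 nM in this assay, at which 1 of the 3 values shown sits, as the only evidence, no step beyond the scatter can be expected in this assay. Compound 4 is expected at 50000 nM, between 20000 nM and 100000 nM. The expected step from compound 1 is a number no higher from compound 1 to compound 4 (the limit leaves the size open), most likely reported again as a limit.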

Compound 4, half-maximal cytotoxic concentration: > 50000 nM
Compound 4: only a limit was reported; the forecaster's own chance of this, stated with the estimate: 85%; the middle value lies on the limit itself.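

Compound 1 and compound 4 both stand at a limit, so oxetan-3-yl in place of cyclopropyl gives no readable step in this assay. The compounds shown leave open the concentration at which any of them becomes cytotoxic.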